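The compounds below may be only part of what the source reports. "The series", "measured", "known", "first", "only" and "open" are said of these compounds alone.

Measured in a functional assay on RPMI-8226 cells (Homo sapiens) for inhibition, read by sulforhodamine B assay, with a stated time of 48 h; on this read-out lower numbers stand for stronger inhibition of growth and higher numbers for weaker inhibition of growth:
Compound 1 `O=C(Cc1csc2nc(-c3ccc(Br)cc3)cn12)N/N=C/c1ccccc1`: > 100000 nM, a limit of the assay.
Compound 2 `O=C(Cc1csc2nc(-c3ccc(Br)cc3)cn12)N/N=C/c1ccccc1O`: 20900 nM.

Going by the values given here, compound 2 gives the only actual number in this assay. Compound 3 `O=C(Cc1csc2nc(-c3ccc(Br)cc3)cn12)N/N=C/c1ccc(O)cc1` differs from it as follows: 4-hydroxyphenyl in place of 2-hydroxyphenyl on a carbon with a double bond to nitrogen. This places 4-hydroxyphenyl in place of 2-hydroxyphenyl on a carbon with a double bond to nitrogen. Among the compounds with values here, one measured step bears on this change, an at least 4.7-fold lower number from compound 1 to compound 2 (0.67 log units; beyond the scatter), with hydroxy in place of hydrogen on an aromatic carbon. Within the data shown here, no measured step moves the hydroxy, so a small rise in the number, or none beyond the scatter, is expected. The expected change is a 1.4-fold higher number from compound 2 to compound 3 (0.16 log units; within the scatter). Compound 3 is estimated at 30000 nM, with an expected range of 10000 nM to 100000 nM.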

Compound 3, concentration for total growth inhibition: 39800 nM
The estimate for compound 3 lay 1.3-fold (0.12 log units) below the measured number, and the stated range covers the measured number.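

Moving the hydroxy from 2-hydroxyphenyl to 4-hydroxyphenyl on the carbon with a double bond to nitrogen leaves the number within the scatter (a 1.9-fold higher number from compound 2 to compound 3 (0.28 log units; within the scatter)), so the two groups are not told apart here. The gain from a hydroxy on the aromatic carbon therefore holds for both groups, not for one alone (an at least 2.5-fold lower number from compound 1 to compound 3 (0.40 log units; beyond the scatter)). Its size remains only a bound, since compound 1 stands at a limit of the assay: the limit of > 100000 nM in this assay, at which 1 of the 3 values shown sits.

Open, going by these compounds, is whether a methoxy, an amine or a carboxylic acid can take the place of the hydroxy. Also open, on these data alone, is whether any such group brings the number well below those of compound 2 and compound 3.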